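A few compounds are considered here, and "the series" means these few. Any claim that something is new, unique, unknown or untested is made for them only; others in the source may bear on it.

For the measured compounds named here, compound 3 `COc1cc2ncnc(NCc3cccc(NC(=O)Nc4ccc(F)cc4)c3)c2cc1OC` gives 36600 nM in a functional assay on HepG2 cells (Homo sapiens) for antiproliferative activity, read by MTT assay (a lower number here means a stronger inhibitor, a higher number a weaker inhibitor), the higher of the two numbers measured so far; compound 2 `COc1cc2ncnc(NCc3cccc(NC(=O)Nc4ccc(C(C)(C)C)cc4)c3)c2cc1OC` gives 6850 nM. Compound 1 `COc1cc2ncnc(NCc3cccc(NC(=O)Nc4ccccc4C)c3)c2cc1OC` gives only a limit of the assay, > 50000 nM. All measured steps change the aryl group on the amide-type nitrogen: a 5.3-fold higher number from compound 2 to compound 3 (0.73 log units; beyond the scatter), an at least 7.2-fold lower number from compound 1 to compound 2 (0.86 log units; beyond the scatter) and an at least 1.3-fold lower number from compound 1 to compound 3 (0.13 log units; that floor lies within the scatter). Compound 4 `COc1cc2ncnc(NCc3cccc(NC(=O)Nc4ccc([N+](=O)[O-])cc4)c3)c2cc1OC` differs from compound 3 by nitro in place of fluoro on an aromatic carbon. Going by the values given here, only the step of a 5.3-fold higher number from compound 2 to compound 3 (0.73 log units; beyond the scatter) altered a group at the same place, and it went from tert-butyl to fluoro; a nitro group is new here, so the direction is open. The analyst therefore expects only a small step, a 1.8-fold lower number from compound 3 to compound 4 (0.26 log units; within the scatter). The estimate for compound 4 in this assay is 20000 nM, between 5000 nM and 50000 nM.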

Compound 4, half-maximal inhibitory concentration: 18800 nM
Compound 4: middle estimate off by 1.1-fold (0.03 log units), on the high side; the measured number falls inside the stated range.
By their numbers in this assay, from the lowest: compound 2; then compounds 4 and 3 (each within the scatter of the next). At a limit, above all of these: compound 1.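

With a 1.9-fold lower number from compound 3 to compound 4 (0.29 log units; within the scatter) in this assay the nitro group and the fluoro group cannot be told apart at this place on the aromatic ring. The tert-butyl group now stands apart from a second group here, with a 2.7-fold higher number from compound 2 to compound 4 (0.44 log units; beyond the scatter) as the new step. The step of an at least 2.6-fold lower number from compound 1 to compound 4 (0.42 log units; beyond the scatter) gives only a floor and rests on a limit: the limit of > 50000 nM in this assay, at which 1 of the 4 values shown sits.

The compounds shown leave open whether an amine or a carboxylic acid at this place would read like tert-butyl or like fluoro and nitro. They also leave open how an isopropyl or ethyl group would read there.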